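A few compounds are considered here, and "the series" means these few. Any claim that something is new, unique, unknown or untested is made for them only; others in the source may bear on it.

compound 1 `COc1ccc(C(=O)c2ccc(OC)c3c2C=CC(C)(C)O3)c(NC(=O)CBr)c1`: 3290 nM
compound 2 `COc1ccc(C(=O)c2ccc3c(c2)C=CC(C)(C)O3)c(NC(=O)CBr)c1`: 2880 nM
compound 3 `COc1ccc(C(=O)c2ccc(OC)c3c2OC(C)(C)C=C3)c(NC(=O)CN)c1`: 410 nM

These values come from a functional assay on MCF7 cells (Homo sapiens) for antiproliferative activity, read by MTT assay, with a stated time of 48 h; a higher number here means a weaker inhibitor, a lower number a stronger inhibitor. Compound 2, at 2880 nM, lies within the scatter of compound 1, at 3290 nM, and well above compound 3, at 410 nM. Compound 4 `CCNCC(=O)Nc1cc(OC)ccc1C(=O)c1ccc2c(c1)C=CC(C)(C)O2` carries ethylamino in place of bromo on a saturated chain carbon bound to a carbonyl carbon. Going by the values given here, no measured pair shows this change alone. Among the compounds with values here, the only compound here without bromo is compound 3, at 410 nM, but its core differs too, so it is weak evidence. A lower number is still expected in this assay, with an estimated 3.2-fold lower number from compound 2 to compound 4 (0.51 log units; beyond the scatter). For compound 4 the expected value is 900 nM, with an estimated range of 250 nM to 2800 nM.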

Compound 4, half-maximal inhibitory concentration: 6310 nM
The estimate for compound 4 lay 7.0-fold (0.85 log units) below the measured number; measured number above the stated range.
By their numbers in this assay, from the lowest: compound 3; then compounds 2, 1 and 4 (each within the scatter of the next, the first and the last beyond it).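

In this assay, going by these compounds alone, this is the first comparison at this position that changes one group alone: putting ethylamino in place of bromo on the saturated chain carbon bound to a carbonyl carbon gives a 2.2-fold higher number from compound 2 to compound 4 (0.34 log units; beyond the scatter) on the shared core. So on this core, removing bromo does not by itself bring a lower number. Nothing measured here explains the step. From the compounds shown here alone, it remains open whether amino, as carried by compound 3, or dimethylamino would give a lower number than ethylamino on the core of compound 2.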